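This account rests on a few compounds, and the source may have more. Where it says the series, first, only, none or still open, it means among the compounds named here.

Two compounds have been measured:

Compound 1, `O=C1OC(c2ccc(Cl)c([N+](=O)[O-])c2)=N/C1=C\c1ccncc1`, in an assay on isolated protein for inhibition of Death-associated protein kinase 3 (Homo sapiens), tested at 1 uM (on this read-out higher numbers stand for a stronger effect at the one concentration tested and lower numbers for a weaker effect), gives 0%.
Compound 2, `COc1ccc(C2=N/C(=C\c3cccnc3)C(=O)O2)cc1Br`, in this assay gives 32%.

Both share the same core and differ in the groups on the two outer rings. Compound 2 stands highest of the two numbers; its nearest neighbour, compound 1, lies a considerable distance below it, and that gap is beyond the usual scatter of this kind of measurement. Compound 1 shows no measurable effect at the single concentration tested, while compound 2 shows a moderate one.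

The next compound, compound 3, `COc1ccc(C2=N/C(=C\c3cccnc3)C(=O)O2)cc1OC`, has not yet been measured. Compared with compound 2 the change is as follows: methoxy in place of bromo on an aromatic carbon. Within the data shown here, no measured pair in this set shows this exact change, so no measured step can be pointed to. The expectation for this assay is a small step, more likely downward than upward, and probably not beyond the scatter. Compound 3 is therefore expected to give about 25%, with a plausible range from 5% to 50%, which would mean an expected step of a number 7 percentage points lower from compound 2 to compound 3 (within the scatter).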

Compound 3, a percentage reported as inhibition, at one concentration (the size of the read-out at that concentration, not a potency): 14%
Compound 3: the middle estimate sits 11 percentage points above what was measured, and the stated range covers the measured number.
By their numbers in this assay, from the lowest: compound 1; then compound 3; then compound 2.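

In this assay, among these compounds, this position offers the first single change that can be read: methoxy in place of bromo, on an aromatic carbon ortho to a methoxy group, gives a number 18 percentage points lower from compound 2 to compound 3 (beyond the scatter) and so shows that the read-out responds to what sits at this one place while the rest of the molecule stays the same. The change does not remove the effect altogether, since compound 3 still gives 14% at the single concentration tested. No measurement shown here explains the difference between bromo and methoxy at this position.

The compounds shown place only bromo and methoxy at this position, so a single step cannot establish a trend, and how an amine, a fluoro group or a longer ether chain would read there remains open. Going by these compounds, it is also open whether this same exchange would give a step of similar size if the rest of the molecule carried other groups.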